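The source may hold more compounds than are shown below. What is called first, only, known or untested is meant among the compounds shown, and "the series" means these compounds.

For the measured compounds named here, compound 3 `CCCCCCCC#CC#CCO` gives 5.48 ug/mL in a functional assay on A549 cells (Homo sapiens) for cytotoxicity (on this read-out higher numbers stand for an effect only at larger amounts of compound and lower numbers for an effect already at smaller amounts), which stands as the highest of the three numbers known, though the gaps to compound 1 `C=CCCCCCC#CC#CC(O)CC(C)=O` with 4.97 ug/mL and to compound 2 `C=CCCCCCCCC#CC#CC(O)CC(C)=O` with 4.91 ug/mL are both within the scatter. Compound 4 `CCCCCCCC#CC#CC(O)CC(C)=O` differs from compound 3 by 2-oxopropyl in place of hydrogen on a saturated chain carbon bound to an oxygen on a saturated carbon and a triple-bonded carbon. Going by the values given here, no measured step repeats this change. Among the compounds with values here, the only measured step, a 1.0-fold lower number from compound 1 to compound 2 (0.01 log units; within the scatter), concerns the far end of the chain and shows that compounds bearing the 2-oxopropyl group give numbers close to compound 3. Compound 4 is therefore expected to lie in the same band, with a step of a 1.1-fold lower number from compound 3 to compound 4 (0.04 log units; within the scatter) not beyond the scatter. The estimate for compound 4 is 5 ug/mL, ranging from 2.5 ug/mL to 10 ug/mL.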

Compound 4, concentration for half-maximal effect: 4.17 ug/mL
For compound 4 the middle estimate is 1.2-fold (0.08 log units) above the measured one; low and high end bracket the measured number.
By their numbers in this assay, from the lowest: compounds 4, 2, 1 and 3 (each within the scatter of the next).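

With 2-oxopropyl in place of hydrogen on the saturated chain carbon bound to an oxygen on a saturated carbon and a triple-bonded carbon, this assay now gives a direct reading of this change: a 1.3-fold lower number from compound 3 to compound 4 (0.12 log units; within the scatter), so the added group does not move the number beyond the scatter. Changes at the far end of the chain also stay small, with a 1.2-fold lower number from compound 2 to compound 4 (0.07 log units; within the scatter) and a 1.2-fold lower number from compound 1 to compound 4 (0.08 log units; within the scatter), so hydrogen in place of vinyl and ethyl in place of vinyl separate nothing here. No evidence on the cause of this flat picture is available. From the compounds shown here alone, what an amine or a carboxylic acid on this carbon would give remains open.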